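The compounds below may be only part of what the source reports. "The series", "measured", "known", "first", "only" and "open" are said of these compounds alone.

Compound 1 `CON/C(=N\C1=NC(=O)C(=O)N1C(C)C)Nc1ccc(Cl)c(Cl)c1` was examined in an in vitro ADME assay on microsomes from liver (Homo sapiens) for metabolic stability, read by LC-MS; a lower number here means that the compound disappears faster, a higher number that the compound lasts longer. In this assay compound 1 gives > 1 h, which is a limit of the assay rather than a number (the limit of > 1 h in this assay, at which 1 of the 3 values shown sits). Two close relatives give numbers: compound 2 `CC(C)N1C(=O)C(=O)N=C1/N=C(\NOCc1ccccc1)Nc1ccc(Cl)c(Cl)c1` gives 0.215 h, and compound 3 `CCCCCCN/C(=N\C1=NC(=O)C(=O)N1C(C)C)Nc1ccc(Cl)c(Cl)c1` gives 0.131 h. Both changes away from compound 1 shortened the half-life: an at least 4.6-fold lower number from compound 1 to compound 2 (0.66 log units; beyond the scatter), and an at least 7.6-fold lower number from compound 1 to compound 3 (0.88 log units; beyond the scatter). Compound 4 `CC(C)N1C(=O)C(=O)N=C1/N=C(\NCCN(C)C)Nc1ccc(Cl)c(Cl)c1` differs from compound 1 at the same amine nitrogen, where (2-(dimethylamino)ethyl in place of methoxy on an amine nitrogen). Since replacing the methoxy by a hexyl chain gave an at least 7.6-fold lower number from compound 1 to compound 3 (0.88 log units; beyond the scatter), a shorter half-life is also expected for compound 4, though the new group differs from a plain chain and the size of the drop is uncertain. For compound 4 the expected step is an at least 2.8-fold lower number from compound 1 to compound 4 (0.45 log units; beyond the scatter). Compound 4 is therefore estimated at 0.35 h, within 0.1 h to 1.2 h.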

Compound 4, half-life: > 1 h
Compound 4 ended at the assay's limit (the forecaster's own chance of this, stated with the estimate: 20%); at least 2.8-fold (0.45 log units) between middle value and limit.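

At this amine nitrogen, a group larger than methoxy need not shorten the half-life in this assay: dimethylamino in place of butyl on the chain gives an at least 7.6-fold higher number from compound 3 to compound 4 (0.88 log units; beyond the scatter), and 2-(dimethylamino)ethyl in place of benzyloxy gives an at least 4.6-fold higher number from compound 2 to compound 4 (0.66 log units; beyond the scatter). Compound 4 stands at a limit of the assay, as does compound 1, and the step between them cannot be read: the limit of > 1 h in this assay, at which 2 of the 4 values shown sit.

Still open, as far as these compounds go, is how long compound 1 and compound 4 actually last. Also open, from the compounds shown here alone, is whether a different end on the chain, such as a morpholine or a carboxylic acid, would give a similarly long half-life.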